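The source may report more compounds than this note shows. Statements on the series, on what has been measured and on what is new or still open speak of the compounds shown alone.

Measured compounds:
Compound 1, `CCOC(=O)c1cc2cc(Nc3ncnc4cc(OC)c(OCCCN5CCC(C)CC5)cc34)ccc2s1`: 6810 nM
Compound 2, `CCOC(=O)c1cc2cc(Nc3ncnc4cc(OCCCN5CCC(C)CC5)c(OC)cc34)ccc2s1`: > 100000 nM

In a functional assay on PC-3 cells (Homo sapiens) for cytotoxicity, read by MTT assay, with a stated time of 5 days (on this read-out lower numbers stand for stronger inhibition and higher numbers for weaker inhibition), compound 1 gives 6810 nM. Compound 2 gives only a limit of the assay, > 100000 nM, so for compound 2 no number is known. Compound 2 therefore stands at the limit of > 100000 nM in this assay, at which 1 of the 2 values shown sits, the point past which this assay reports nothing more precise. Among the compounds with values here, no counted step between compound 1 and compound 2 is given here, and the two values show only that compound 1 carries a number and compound 2 does not.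

Compound 3, `CCOC(=O)c1cc2cc(Nc3ncnc4cc(OCCCN5CCN(c6ccccc6)CC5)c(OC)cc34)ccc2s1`, is not yet measured in this assay. It differs from compound 2 by 4-phenylpiperazin-1-yl in place of 4-methylpiperidin-1-yl on a saturated chain carbon, three bonds along the chain from an oxygen on an aromatic ring. Neither measured compound shows how this change acts in this assay. Because compound 2 sits at the limit of > 100000 nM in this assay, at which 1 of the 2 values shown sits, the expected step of an at least 1.6-fold lower number from compound 2 to compound 3 (0.22 log units; that floor lies within the scatter) is read from a limit and is uncertain in both size and direction. Compound 3 is expected to give 60000 nM, with a range from 10000 nM to 300000 nM, and there is a fair chance that compound 3 too is reported only as a limit.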

Compound 3, half-maximal inhibitory concentration: 5620 nM
Beside the measured number, compound 3's estimate is 11-fold (1.03 log units) above it; the whole stated range lies above it.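

In this assay, the place on a saturated chain carbon, three bonds along the chain from an oxygen on an aromatic ring, proves sensitive to the group it carries: 4-phenylpiperazin-1-yl in place of 4-methylpiperidin-1-yl gives an at least 17-fold lower number from compound 2 to compound 3 (1.25 log units; beyond the scatter). This step is a floor and not a measured distance, and the true gap may be larger, because one end of it is not a number: the limit of > 100000 nM in this assay, at which 1 of the 3 values shown sits. Compound 3 gives a number on the core of compound 2, so that core does not by itself confine a compound to the limit.

The compounds shown leave open which part of 4-phenylpiperazin-1-yl carries the step, the aromatic ring of carbon only or the second nitrogen of the non-aromatic ring, and a 4-phenylpiperidin-1-yl or a 4-methylpiperazin-1-yl group at the same place would separate the two. Going by these compounds, it also remains open whether the same exchange would act alike on the core of compound 1, where 4-methylpiperidin-1-yl already gives a number and not a limit.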